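Ethenyl-Linked Ring in Place of tert-Butyl

The source may hold more compounds than are shown below. What is called first, only, known or untested is meant among the compounds shown, and "the series" means these compounds.

The series shares the core of compound 1 `COC(=O)/C=C/c1cccc(N(Cc2ccc(-c3ccc(F)c(F)c3)cc2)C(=O)C2CCCCC2)c1`, which in an assay on isolated protein with Bile acid receptor (Homo sapiens) as the target (on this read-out higher numbers stand for an effect only at larger amounts of compound and lower numbers for an effect already at smaller amounts), gives 72 nM. Compound 2 `COC(=O)/C=C/c1cccc(N(Cc2cccc(Br)c2)C(=O)C2CCCCC2)c1` carries 3-bromophenyl; in this assay compound 2 reaches only the limit > 1000 nM. Compound 3 `COC(=O)/C=C/c1cccc(N(Cc2ccc(C(C)(C)C)cc2)C(=O)C2CCCCC2)c1`, with tert-butyl, likewise stands at the limit > 1000 nM. Compound 3 therefore sits at the weak end of the three values shown, together with compound 2. The loss on exchanging 3,4-difluorophenyl for tert-butyl is an at least 13-fold higher number from compound 1 to compound 3 (1.14 log units; beyond the scatter); by contrast a step that the two limits leave unreadable from compound 2 to compound 3 cannot be sized because both values rest on (the limit of > 1000 nM in this assay, at which 2 of the 3 values shown sit).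

Compound 4 `COC(=O)/C=C/c1cccc(N(Cc2ccc(/C=C/c3ccc(F)cc3)cc2)C(=O)C2CCCCC2)c1` differs from compound 3 by 2-(4-fluorophenyl)ethenyl in place of tert-butyl on an aromatic carbon. Among the compounds with values here, an aromatic ring thus returns at the position tert-butyl occupies in compound 3, so the bearing step is the one from compound 1 to compound 3, which was large; the step from compound 2 to compound 3 gives no size. A gain is expected in this assay, with an at least 6.6-fold lower number from compound 3 to compound 4 (0.82 log units; beyond the scatter) as the expected step. For compound 4 the estimated value is 150 nM, within 40 nM to 800 nM.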

Compound 4, half-maximal effective concentration: 185 nM
Compound 4: the middle estimate sits 1.2-fold (0.09 log units) below what was measured; the measured number falls inside the stated range.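

In this assay, the aromatic carbon that carries tert-butyl in compound 3 also takes 2-(4-fluorophenyl)ethenyl, with an at least 5.4-fold lower number from compound 3 to compound 4 (0.73 log units; beyond the scatter), so activity at this position does not rest on the 3,4-difluorophenyl group of compound 1 alone. That group still holds an edge, with a 2.6-fold higher number from compound 1 to compound 4 (0.41 log units; beyond the scatter), but this exchange alters both the ethenyl link and the fluorine pattern, so neither can be credited separately. The gain over compound 3 can be read only as a lower bound, since its starting point is a limit and not a number: the limit of > 1000 nM in this assay, at which 2 of the 4 values shown sit.

From the compounds shown here alone, the separate contributions of the ethenyl link and the fluorine remain open. Also open, going by these compounds, is how the series responds to an amine or a carboxylic acid in place of that fluorine.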